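A few compounds are considered here, and "the series" means these few. Any claim that something is new, unique, unknown or untested is made for them only; others in the source may bear on it.

Measured in a functional assay on KB cells (Homo sapiens) for cytotoxicity, read by MTT assay, with a stated time of 72 h; a lower number here means a stronger inhibitor, a higher number a weaker inhibitor:
- compound 1 `COc1cc(Nc2nc3ccccc3nc2S(=O)(=O)c2ccc(Br)cc2)cc(OC)c1`: "not determined" (no result reported)
- compound 2 `Nc1ccc(Nc2nc3ccccc3nc2S(=O)(=O)c2ccc(Br)cc2)cc1`: 4080 nM

Within the data shown here, compound 2 holds the only number so far, so it cannot be ranked, because compound 1 has no result to set beside it. The next structure, compound 3 `O=S(=O)(c1ccc(Br)cc1)c1nc2ccccc2nc1Nc1cccc(O)c1`, keeps the shared core and differs in one place: 3-hydroxyphenyl in place of 4-aminophenyl on a nitrogen on an aromatic ring. Here 3-hydroxyphenyl stands in place of 4-aminophenyl on a nitrogen on an aromatic ring. Among the measured compounds shown here, no pair of measured compounds shows how much a change of this kind moves the read-out in this assay, so no direction can be argued firmly. The expectation therefore stays anchored on compound 2 at 4080 nM, with no change beyond the scatter. The estimated step of a 1.2-fold higher number from compound 2 to compound 3 (0.09 log units; within the scatter) is small. Compound 3 is expected at about 5000 nM, with an estimated range of 1500 nM to 16000 nM.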

Compound 3, half-maximal inhibitory concentration: 8410 nM
Beside the measured number, compound 3's estimate is 1.7-fold (0.23 log units) below it; the range from low to high includes it.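

Among these compounds, putting 3-hydroxyphenyl in place of 4-aminophenyl on a nitrogen on an aromatic ring gives the first readable step at this position in this assay: a 2.1-fold higher number from compound 2 to compound 3 (0.31 log units; beyond the scatter) is a modest move, just past the usual scatter of repeated measurements. The two groups match in every count, with the same ring and the same numbers of heavy atoms, donors and acceptors, yet the swap changes both the atom and its place on the ring, and this single step cannot separate those two changes. Nothing measured here explains the step.

Still open, on these data alone, is how a 3-aminophenyl or a 4-hydroxyphenyl group would read, since either would separate the atom from its place on the ring. Also open, as far as these compounds go, is whether a carboxylic acid or a methoxy group at this position would move the number further, and in which direction.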